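This account rests on a few compounds, and the source may have more. Where it says the series, first, only, none or still open, it means among the compounds named here.

Compound 1 `CCOC(=O)CSc1nnc(-c2cc(OC)c(OC)c(OC)c2)n1-c1ccc(OC)cc1` carries the ethoxycarbonyl chain on the shared core. In a functional assay on PC-3 cells (Homo sapiens) for inhibition, read by MTT assay, with a stated time of 48 h (a lower number here means a stronger inhibitor, a higher number a weaker inhibitor), compound 1 gives > 60000 nM, which is a limit of the assay and not a number. Compound 2 `COc1ccc(NC(=O)CSc2nnc(-c3cc(OC)c(OC)c(OC)c3)n2-c2ccc(OC)cc2)cc1` differs from it by (4-methoxyphenyl)amino in place of ethoxy on a carbonyl carbon; in this assay compound 2 gives 25800 nM. That change made an at least 2.3-fold lower number from compound 1 to compound 2 (0.36 log units; beyond the scatter), a step measured from the limit of > 60000 nM in this assay, at which 2 of the 3 values shown sit. Compound 3 `CCOC(=O)CSc1nnc(-c2cc(OC)c(OC)c(OC)c2)n1-c1ccc(N(C)C)cc1` differs from compound 1 by dimethylamino in place of methoxy on an aromatic carbon. In this assay compound 3 gives > 60000 nM, again a limit of the assay. The step that the two limits leave unreadable from compound 1 to compound 3 is therefore not readable. Compound 4 `COc1ccc(NC(=O)CSc2nnc(-c3cc(OC)c(OC)c(OC)c3)n2-c2ccc(N(C)C)cc2)cc1` is not yet measured; it differs from compound 3 by (4-methoxyphenyl)amino in place of ethoxy on a carbonyl carbon, the same change as between the first two compounds. If that change repeats on the second core, an estimated at least 2.0-fold lower number from compound 3 to compound 4 (0.30 log units; that floor lies within the scatter) is expected, resting on the step of an at least 2.3-fold lower number from compound 1 to compound 2 (0.36 log units; beyond the scatter). Compound 4 is estimated at 30000 nM, expected between 10000 nM and 100000 nM.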

Compound 4, half-maximal inhibitory concentration: 56100 nM
Compound 4: middle estimate off by 1.9-fold (0.27 log units), on the low side, and the stated range covers the measured number.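

In this assay, (4-methoxyphenyl)amino in place of ethoxy on a carbonyl carbon gives an at least 1.0-fold lower number from compound 3 to compound 4 (0.02 log units; that floor lies within the scatter), which neither shows a real gain on the second core nor rules one out. Set beside the first core, the change cannot be said to carry over either fully or weakly: the same change on two cores in this assay, an at least 2.3-fold lower number (0.36 log units; beyond the scatter) from compound 1 to compound 2 and an at least 1.0-fold lower number (0.02 log units; that floor lies within the scatter) from compound 3 to compound 4; the limit leaves it open whether they differ. With (4-methoxyphenyl)amino in place, dimethylamino in place of methoxy on an aromatic carbon gives a 2.2-fold higher number from compound 2 to compound 4 (0.34 log units; beyond the scatter), whereas the same change with ethoxy on the carbonyl carbon cannot be read.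

On these data alone, the true size of each step measured from a limit stays open: the limit of > 60000 nM in this assay, at which 2 of the 4 values shown sit. Also open, as far as these compounds go, is whether a carboxylic acid or a benzylamino group on the carbonyl carbon would behave alike on both cores.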